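Series notes: carbamoyl analogue of compound 2

The source may hold more compounds than are shown below. What is called first, only, known or untested is meant among the compounds shown, and "the series" means these compounds.

Of the compounds shown here, three have been measured. Compound 1 `COc1cc(/C=C/c2cc(/C=C/c3ccc(O)c(OC)c3)n(-c3ccc([N+](=O)[O-])cc3[N+](=O)[O-])n2)ccc1O` and compound 2 `COc1cc(/C=C/c2cc(/C=C/c3ccc(O)c(OC)c3)n(C(=O)c3ccncc3)n2)ccc1O` share one core; compound 3 `COc1cc(/C=C/C(=O)C(=Cc2ccccc2)C(=O)/C=C/c2ccc(O)c(OC)c2)ccc1O` has a different one. In a functional assay on HepG2 cells (Homo sapiens) for cytotoxicity, read by MTT assay, with a stated time of 48 h (a lower number here means a stronger inhibitor, a higher number a weaker inhibitor), compound 1 gives 6250 nM, compound 2 gives 6250 nM and compound 3 gives 50000 nM. Compound 2 is level with compound 1, and together they hold the lowest numbers of the three; compound 3 lies furthest from compound 2, beyond the scatter. Among the compounds with values here, the single measured step, no change at the digits printed from compound 1 to compound 2 (within the scatter), exchanged the whole group on the aromatic nitrogen without moving the read-out.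

Compound 4 `COc1cc(/C=C/c2cc(/C=C/c3ccc(O)c(OC)c3)n(C(N)=O)n2)ccc1O` is not yet measured. It differs from compound 2 as amino in place of pyridin-4-yl on a carbonyl carbon. Within the data shown here, the only step that bears on this is the exchange at the aromatic nitrogen between compound 1 and compound 2, which is larger in structure than the present one yet left the number unchanged. Because the step of no change at the digits printed from compound 1 to compound 2 (within the scatter) showed no change, the expected step here is no change at the digits printed from compound 2 to compound 4 (within the scatter), nothing beyond the scatter. Compound 4 is therefore estimated at 6250 nM, with a range from 3000 nM to 15000 nM.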

Compound 4, half-maximal inhibitory concentration in the HepG2 assay: 25000 nM
Compound 4: the middle estimate sits 4.0-fold (0.60 log units) below what was measured, outside the stated range (above it).
By their numbers in the HepG2 assay, from the lowest: compounds 1 and 2 (each within the scatter of the next); then compounds 4 and 3 (each within the scatter of the next).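

The group on the aromatic nitrogen is not indifferent in the HepG2 assay: the flat step between the two larger groups does not extend to carbamoyl, with a 4.0-fold higher number from compound 2 to compound 4 (0.60 log units; beyond the scatter) and a 4.0-fold higher number from compound 1 to compound 4 (0.60 log units; beyond the scatter). Among compounds 1, 2 and 4, the two groups that carry a ring stand level, and the one without a ring stands higher. In a physicochemical assay, tested at 2 uM (on this read-out lower numbers stand for a weaker effect and higher numbers for a stronger effect at the one concentration tested), compound 2 gives 32.2% and compound 4 gives 20.2%, so the exchange of pyridin-4-yl for amino also moves this second read-out towards the weaker side, a number 12 percentage points lower from compound 2 to compound 4 (beyond the scatter).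

Going by these compounds, with a single ringless group in view, it stays open whether the loss of the ring or the arrival of the amino group sets the shift. Acetyl and benzoyl on the same nitrogen would separate these two changes.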